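The source may hold more compounds than are shown below. What is called first, only, known or untested is meant among the compounds shown, and "the series" means these compounds.

Compound 1 `CN(C)CCN1CCN(c2nc(-c3ccccn3)nc3c2CN(Cc2ccccc2)CC3)CC1`: 41.3%
Compound 2 `CN(C)CCN1CCN(c2nc(-c3ccccn3)nc3c2CN(Cc2ccsc2)CC3)CC1`: 79.8%

For the measured compounds named here, in an assay on FRT cells with Cystic fibrosis transmembrane conductance regulator variant F508del (Homo sapiens) as the target, read by fluorescence, with a stated time of 25 min (a higher number here means a larger maximal response, a lower number a smaller maximal response), compound 2 gives 79.8%, the higher of the two numbers measured so far. Going by the values given here, the only other measured compound, compound 1, sits lower by the step of a number 38.5 percentage points higher from compound 1 to compound 2 (beyond the scatter), which is beyond the scatter; that step came from putting thiophen-3-yl in place of phenyl on a saturated chain carbon bound to an amine nitrogen in a ring.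

Compound 3 `CN(C)CCN1CCN(c2nc(-c3ccccn3)nc3c2CN(S(=O)(=O)c2ccccc2)CC3)CC1` has not yet been measured. It differs from compound 2 in one place: phenylsulfonyl in place of (thiophen-3-yl)methyl on an amine nitrogen in a ring

Among the compounds with values here, no measured step bears directly on this change. Within the data shown here, the one step known kept the saturated chain carbon and exchanged only the ring on it, whereas here the whole (thiophen-3-yl)methyl leaves and phenylsulfonyl enters. Compound 1, which carries phenyl, gives 41.3%, so a fall back toward that level seems somewhat more likely than a further rise, but the uncertainty is wide. For compound 3 the estimated value in this assay is 45%, with a range from 15% to 75%. This amounts to an expected step of a number 34.8 percentage points lower from compound 2 to compound 3 (beyond the scatter).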

Compound 3, largest response reached (Emax), in percent of the reference or control that the assay uses: "not active" (no number reported)
No number was reported for compound 3; there is nothing to compare the estimate with.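

For the compounds shown here, compound 3 is reported as "not active" in this assay, without a number, so no step from compound 2 to compound 3 can be read. The compounds shown leave open whether the phenylsulfonyl group entering or the (thiophen-3-yl)methyl group leaving accounts for this outcome. Nothing measured here explains the result.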